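The source may hold more compounds than are shown below. What is called first, only, known or untested is meant among the compounds shown, and "the series" means these compounds.

Among the compounds with values here, compound 3 `CN(C)c1ccc(/C=C2\S/C(=N\c3csc(-c4ccc(Cl)cc4)c3)NC2=O)cc1` is the only member of this small set that gives a number in a functional assay on MCF7 cells (Homo sapiens) for cytotoxicity, read by MTT assay, with a stated time of 72 h (on this read-out higher numbers stand for weaker inhibition and lower numbers for stronger inhibition), where compound 3 gives 400 nM. Compound 1 `Cc1ccc(-c2cc(/N=C3/NC(=O)CS3)cs2)cc1` gives > 50000 nM in this assay, which is a limit rather than a number. Compound 2 `O=C1CS/C(=N\c2csc(-c3ccc(Cl)cc3)c2)N1` likewise gives > 50000 nM in this assay, again a limit. Within the data shown here, the one step that can be traced between measured compounds, a step that the two limits leave unreadable from compound 1 to compound 2, is therefore not readable in size, as the two values sit at the limit of > 50000 nM in this assay, at which 2 of the 3 values shown sit. Compound 4 `COc1ccc(/C=C2\S/C(=N\c3csc(-c4ccc(Cl)cc4)c3)NC2=O)cc1OC` differs from compound 3 by 3,4-dimethoxyphenyl in place of 4-(dimethylamino)phenyl on a double-bonded chain carbon bound to a double-bonded ring carbon. Among the measured compounds shown here, no measured step touches this position, so nothing traced here bears directly on the change; the two limits give no guide either. With compound 3 as the only anchor, a step of modest size in either direction, or none beyond the scatter, is the most that can be expected, and the step from compound 3 to compound 4 is estimated at a 2.0-fold higher number from compound 3 to compound 4 (0.30 log units; within the scatter). Compound 4 is expected to give about 800 nM in this assay, within a range from 200 nM to 4000 nM.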

Compound 4, half-maximal inhibitory concentration: 7600 nM
Compound 4: middle estimate off by 9.5-fold (0.98 log units), on the low side, outside the stated range (above it).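

In this assay, the group on the double-bonded chain carbon bound to a double-bonded ring carbon proves to matter a great deal: 3,4-dimethoxyphenyl in place of 4-(dimethylamino)phenyl gives a 19-fold higher number from compound 3 to compound 4 (1.28 log units; beyond the scatter). Within the data shown here, the earlier compounds offered only one number for this position, whereas this result shows that two groups, each with one six-membered aromatic ring of carbon only, are not interchangeable there. Compound 4 still gives a number and does not join compound 1 and compound 2 at the limit: the limit of > 50000 nM in this assay, at which 2 of the 4 values shown sit.

The compounds shown do not separate the loss of the dimethylamino group from the entry of the two methoxy groups, so it remains open whether a plain phenyl, a 4-methoxyphenyl or a 4-aminophenyl would stand nearer compound 3 or compound 4. As far as these compounds go, it also remains open whether this step would keep its size with methyl in place of chloro elsewhere on the shared core.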